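This account rests on a few compounds, and the source may have more. Where it says the series, first, only, none or still open, it means among the compounds named here.

Measured so far in a functional assay on HepG2 cells (Homo sapiens) for cytotoxicity, read by MTT assay, with a stated time of 48 h; a higher number here means a weaker inhibitor, a lower number a stronger inhibitor:
compound 1 `CCCCOC(=O)/C=C/c1ccc2c(c1)C(=O)C(=O)N2Cc1ccc(OC)cc1` gives 630 nM;
compound 2 `COc1ccc(CN2C(=O)C(=O)c3cc(/C=C/C(=O)OCCO)ccc32)cc1` gives 860 nM;
compound 3 `O=C(/C=C/c1ccc2c(c1)C(=O)C(=O)N2Cc1ccc(Br)cc1)OCCO` gives 3660 nM.

Compound 4 `CCCCOC(=O)/C=C/c1ccc2c(c1)C(=O)C(=O)N2Cc1ccc(Br)cc1` is not yet measured. It stands to compound 3 as compound 1 stands to compound 2: the same change, (ethyl in place of hydroxy on a saturated chain carbon, two bonds along the chain from an oxygen next to a carbonyl group), which in the measured pair reads ethyl in place of hydroxy on a saturated chain carbon, two bonds along the chain from an oxygen next to a carbonyl group and produced a step of a 1.4-fold lower number from compound 2 to compound 1 (0.14 log units; within the scatter). The cores of the two pairs differ by bromo in place of methoxy on an aromatic carbon, a change that moved the number by a 4.3-fold higher number from compound 2 to compound 3 (0.63 log units; beyond the scatter), leaving compound 3 with the highest of the three values.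

For compound 4 in this assay a step of about a 1.4-fold lower number from compound 3 to compound 4 (0.15 log units; within the scatter) is expected, a small one, because a 1.4-fold lower number from compound 2 to compound 1 (0.14 log units; within the scatter) stayed within the scatter when the same change was made on the other core. On that basis compound 4 is estimated at 2600 nM, with a range from 1200 nM to 5500 nM.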

Compound 4, half-maximal inhibitory concentration: 650 nM
Compound 4: the middle estimate sits 4.0-fold (0.60 log units) above what was measured; measured number outside the range, below it.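

In this assay, putting ethyl in place of hydroxy on the bromo core gives a 5.6-fold lower number from compound 3 to compound 4 (0.75 log units; beyond the scatter), so the step seen on the methoxy core does not carry over at the same size: the same change on two cores in this assay, a 1.4-fold lower number (0.14 log units; within the scatter) from compound 2 to compound 1 and a 5.6-fold lower number (0.75 log units; beyond the scatter) from compound 3 to compound 4, 4.1-fold (0.62 log units) apart, beyond the scatter of two such steps

Read the other way, bromo in place of methoxy on the butoxy esters gives a 1.0-fold higher number from compound 1 to compound 4 (0.01 log units; within the scatter), so that change also depends on the core that carries it: the same change on two cores in this assay, a 4.3-fold higher number (0.63 log units; beyond the scatter) from compound 2 to compound 3 and a 1.0-fold higher number (0.01 log units; within the scatter) from compound 1 to compound 4, 4.1-fold (0.62 log units) apart, beyond the scatter of two such steps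

These four compounds show that the two changes are not independent here, but not why, nor how the changes would behave on any other core.

Still open, from the compounds shown here alone, is whether the same dependence holds with a longer chain or an amine in place of butoxy, or with chloro in place of bromo.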